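This account rests on a few compounds, and the source may have more. Where it says the series, first, only, none or still open, it means among the compounds named here.

Of the compounds shown here, three have so far been tested in a functional assay on MIA PaCa-2 cells (Homo sapiens) for inhibition, read by MTT assay, with a stated time of 72 h; on this read-out lower numbers stand for stronger inhibition and higher numbers for weaker inhibition. Compound 1 `O=C(Nc1cc(F)cc2cccnc12)c1ncccn1` gives 300 nM in this assay. Compound 2 `Cc1cnc(C(=O)Nc2cc(OCCN)cc3cccnc23)cn1` reaches only the limit of this assay, > 10000 nM, which is a limit rather than a measured number. Compound 3 `CC(C)(C)OC(=O)NCCOc1cc(NC(=O)c2ncccn2)c2ncccc2c1` likewise shows only a limit in this assay, > 10000 nM. Compound 3 therefore stands where no number is available at all, and the same holds for most of the set, since (the limit of > 10000 nM in this assay, at which 2 of the 3 values shown sit).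

Compound 4 `NCCOc1cc(NC(=O)c2ncccn2)c2ncccc2c1` has not yet been measured. It differs from compound 3 in one place: hydrogen in place of tert-butoxycarbonyl on an amine nitrogen. Among the measured compounds shown here, no two measured compounds differ in a single place, so no measured step can be read off for this change. Compound 2 also carries an amine bearing hydrogen on its chain, and in this assay compound 2 sits at the limit, > 10000 nM. The step is expected to be an at least 1.2-fold lower number from compound 3 to compound 4 (0.09 log units; that floor lies within the scatter), not beyond the scatter. Compound 4 is therefore expected to give about 8000 nM in this assay, within a range from 1500 nM to 30000 nM.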

Compound 4, half-maximal inhibitory concentration: > 10000 nM
Compound 4: only a limit was reported (the forecaster's own chance of this, stated with the estimate: 55%); at least 1.2-fold (0.09 log units) between middle value and limit.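

Replacing tert-butoxycarbonyl with hydrogen on the amine nitrogen does not bring the series back into a measurable range: in this assay, compound 4 gives only a limit, > 10000 nM. Among the compounds shown here, the one readable step concerns the aromatic carbon that carries fluoro in compound 1, where 2-aminoethoxy in place of fluoro gives an at least 33-fold higher number from compound 1 to compound 4 (1.52 log units; beyond the scatter). The steps to compound 4 from compound 2 and from compound 3 cannot be read because both ends of each are limits: the limit of > 10000 nM in this assay, at which 3 of the 4 values shown sit.

The compounds shown leave open whether this loss goes with the amine or with the ethoxy chain itself, a question that a methoxy or 2-hydroxyethoxy group on that aromatic carbon could address. They also leave open how far beyond the limit compound 2, compound 3 and compound 4 lie.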